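A few compounds are considered here, and "the series" means these few. Any claim that something is new, unique, unknown or untested is made for them only; others in the source may bear on it.

Measured in a functional assay on Ehrlich cells (Mus musculus) for inhibition; on this read-out lower numbers stand for stronger inhibition and higher numbers for weaker inhibition:

- compound 1 `O=C(O)c1cnc2cc(OCc3cccc4ccccc34)ccc2c1O`: 85100 nM
- compound 2 `O=C(O)c1cnc2cc(O)ccc2c1O`: 912000 nM

Of these two compounds, compound 2 has the higher number at 912000 nM, which means the weaker inhibition, and its gap to compound 1 lies beyond the usual scatter of this assay. The next compound to be tested is compound 3 `NC(=O)c1ccc2c(O)c(C(=O)O)cnc2c1`, which has not yet been measured. It carries carbamoyl in place of hydroxy on an aromatic carbon of compound 2: carbamoyl in place of hydroxy on an aromatic carbon. Going by the values given here, no measured pair of compounds isolates this kind of exchange, so the expectation rests on little. The lower number of compound 1, 85100 nM, goes with a substituent much larger than either group exchanged here, whereas carbamoyl is only a modest enlargement. No shift beyond the scatter is therefore expected, and the estimated step of a 1.3-fold lower number from compound 2 to compound 3 (0.11 log units; within the scatter) is small. For compound 3 the expected value is 700000 nM, with an estimated range of 220000 nM to 2000000 nM.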

Compound 3, half-maximal inhibitory concentration: 5750000 nM
Compound 3: middle estimate off by 8.2-fold (0.91 log units), on the low side, outside the stated range (above it).
By their numbers in this assay, from the lowest: compound 1; then compound 2; then compound 3.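

In this assay, the exchange of carbamoyl for hydroxy on an aromatic carbon gives a 6.3-fold higher number from compound 2 to compound 3 (0.80 log units; beyond the scatter), so inhibition at this position weakens beyond the scatter. Going by these compounds alone, this is the first exchange here that can be read in isolation, and it shows that the read-out responds even when hydroxy, with 1 heavy atom, gives way to carbamoyl, with 3 heavy atoms, although the counted hydrogen-bond donors and acceptors stay the same and neither group carries a net charge. No measurement available here explains why the number rises with this exchange.

The compounds shown leave open whether the step belongs to the arrival of carbamoyl or to the loss of hydroxy, since neither a plain hydrogen nor a methoxy group at this position is among them. They also leave open how an amine, a carboxylic acid or a longer chain carrying the amide at the same aromatic carbon would compare with compound 2 and compound 3.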